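The source may hold more compounds than are shown below. What is called first, only, known or untested is meant among the compounds shown, and "the series" means these compounds.

In a functional assay on VCaP cells (Homo sapiens) for antiproliferative activity, read by propidium iodide staining, with a stated time of 96 h (on this read-out higher numbers stand for weaker inhibition and lower numbers for stronger inhibition), compound 1 (`CC(O)(COc1cccc(C(F)(F)F)c1)C(=O)Nc1ccc(S(F)(F)(F)(F)F)cc1`) gives 24700 nM. Compound 2 (`CC(O)(COc1cccc(OC(F)(F)F)c1)C(=O)Nc1ccc(S(F)(F)(F)(F)F)cc1`) gives 18300 nM, and compound 3 (`CC(O)(COc1ccc(C#N)cc1)C(=O)Nc1ccc(S(F)(F)(F)(F)F)cc1`) gives 100000 nM. Compound 1 therefore stands level with compound 2 and well clear of compound 3.

Compound 4 (`CC(O)(COc1cc(C(F)(F)F)cc(C(F)(F)F)c1)C(=O)Nc1ccc(S(F)(F)(F)(F)F)cc1`) keeps the core of compound 1 but gains a second trifluoromethyl group, meta to a trifluoromethyl group: trifluoromethyl in place of hydrogen on an aromatic carbon. Going by the values given here, no measured step adds a group in this way, so the evidence is indirect. Trifluoromethoxy in place of trifluoromethyl gave a 1.3-fold lower number from compound 1 to compound 2 (0.13 log units; within the scatter), so that change on the ring left the number within the scatter. 4-Cyanophenyl in place of 3-(trifluoromethyl)phenyl gave a 4.0-fold higher number from compound 1 to compound 3 (0.61 log units; beyond the scatter), and this removal of the trifluoromethyl group went with a higher number. That points, weakly, to a small move the other way when a trifluoromethyl group is added. The estimated step is a 1.8-fold lower number from compound 1 to compound 4 (0.25 log units; within the scatter), a small one toward a lower number. The expected value for compound 4 is 14000 nM, with an estimated range from 5000 nM to 35000 nM.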

Compound 4, half-maximal inhibitory concentration: 2600 nM
Compound 4: the middle estimate sits 5.4-fold (0.73 log units) above what was measured; the whole stated range lies above it.
By their numbers in this assay, from the lowest: compound 4; then compounds 2 and 1 (each within the scatter of the next); then compound 3.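

Adding a trifluoromethyl group to this aromatic carbon gives a 9.5-fold lower number from compound 1 to compound 4 (0.98 log units; beyond the scatter) and is the only step shown that goes beyond the scatter toward a lower number. The earlier compounds shown here showed a swap on the existing ring group that stayed within the scatter and a change of ring substitution that moved the number upward, whereas this step shows that filling this previously empty carbon can by itself lower the number clearly. The compounds come with no measurement that would explain this drop, so the result stands as an observation only.

From the compounds shown here alone, what a chlorine atom, a methoxy group or an amine on this same carbon would do remains open. Also open, going by these compounds, is whether the new trifluoromethyl group would give a similar step on a ring lacking the first one.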